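The compounds below may be only part of what the source reports. "The series", "measured", "known", "first", "only" and "open" are said of these compounds alone.

Working notes on the series. Within the data shown here, compound 3 `COc1cccc(Nc2nc(Nc3cc(C)[nH]n3)cc(N3CCN(C)CC3)n2)c1` gives 192 nM in a functional assay on MOLT-4 cells (Homo sapiens) for antiproliferative activity, read by CCK-8 assay, with a stated time of 72 h (on this read-out higher numbers stand for weaker inhibition and lower numbers for stronger inhibition), the highest of the three numbers so far; compound 2 `COc1ccc(Nc2nc(Nc3cc(C)[nH]n3)cc(N3CCN(C)CC3)n2)cc1` stands nearest at 116 nM, and compound 1 `Cc1cc(Nc2cc(N3CCN(C)CC3)nc(Nc3cccc(Cl)c3)n2)n[nH]1` furthest at 20.1 nM. The steps of a 5.8-fold higher number from compound 1 to compound 2 (0.76 log units; beyond the scatter) and a 9.6-fold higher number from compound 1 to compound 3 (0.98 log units; beyond the scatter) both point the same way, while a 1.7-fold higher number from compound 2 to compound 3 (0.22 log units; within the scatter) does not. Compound 4 `Cc1cc(Nc2cc(N3CCN(C)CC3)nc(Nc3ccc([N+](=O)[O-])cc3)n2)n[nH]1` differs from compound 3 by 4-nitrophenyl in place of 3-methoxyphenyl on a nitrogen on an aromatic ring. Among the measured compounds shown here, no measured step exchanges a methoxy group for a nitro group, so the two comparable steps are those from compound 1, and they only show that the aryl substituent can shift the number by a modest amount. For compound 4 a step of a 1.9-fold lower number from compound 3 to compound 4 (0.28 log units; within the scatter) is expected, toward a lower number but uncertain in size. Compound 4 is therefore estimated at 100 nM, within 30 nM to 400 nM.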

Compound 4, half-maximal inhibitory concentration: 18.1 nM
Compound 4: middle estimate off by 5.5-fold (0.74 log units), on the high side; the whole stated range lies above it.
By their numbers in this assay, from the lowest: compounds 4 and 1 (each within the scatter of the next); then compounds 2 and 3 (each within the scatter of the next).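

In this assay the group on this nitrogen moves the number strongly downward when 4-nitrophenyl replaces 3-methoxyphenyl, with an 11-fold lower number from compound 3 to compound 4 (1.03 log units; beyond the scatter) and a matching shift of a 6.4-fold lower number from compound 2 to compound 4 (0.81 log units; beyond the scatter) for nitro in place of methoxy on an aromatic carbon. Low numbers are not unique to 3-chlorophenyl, since a 1.1-fold lower number from compound 1 to compound 4 (0.05 log units; within the scatter) leaves 4-nitrophenyl level with it, while both methoxyphenyl compounds stand higher. No measurement here bears on the reason for this shift. Open, from the compounds shown here alone, is whether an amine or a carboxylic acid on this aromatic ring would give numbers like the nitro and chloro compounds or like the methoxy compounds.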